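The source may hold more compounds than are shown below. What is called first, only, known or untested is meant among the compounds shown, and "the series" means these compounds.

Values in an ADME assay on U-937 cells (Homo sapiens) for cytotoxicity, read by MTT assay, with a stated time of 72 h (a lower number here means that less compound is tolerated, a higher number that more compound is tolerated), follow
- Compound 1 `O=C(/C=C/c1ccc(O)c(O)c1)OCCCCCCCOc1cc(Cl)ccc1Oc1ccc(Cl)cc1Cl` gives 20000 nM
- Compound 2 `O=C(/C=C/c1ccc(O)c(O)c1)OCCCCCCCCCOc1cc(Cl)ccc1Oc1ccc(Cl)cc1Cl` gives 3620 nM
- Compound 3 `COc1ccc(/C=C/C(=O)OCCCOc2cc(Cl)ccc2Oc2ccc(Cl)cc2Cl)cc1OC` gives > 371000 nM (a limit)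

Of these three results, only compound 3 gives a limit (> 371000 nM) and not a number. Compound 4 `O=C(/C=C/c1ccc(O)c(O)c1)OCCCOc1cc(Cl)ccc1Oc1ccc(Cl)cc1Cl` differs from compound 3 by having 3,4-dihydroxyphenyl in place of 3,4-dimethoxyphenyl on a double-bonded chain carbon bound to a double-bonded chain carbon. Compound 1 (20000 nM) carries the same 3,4-dihydroxyphenyl group, as does compound 2 (3620 nM), and both give measured numbers. A downward move beyond the scatter in this assay is therefore expected, with the expected at least 6.1-fold lower number from compound 3 to compound 4 (0.79 log units; beyond the scatter) as its size. Compound 4 is estimated at 60000 nM (expected range 12000 nM to 300000 nM).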

Compound 4, concentration lethal to 50% of the cells: > 392000 nM
Compound 4: only a limit was reported; the forecaster's own chance of this, stated with the estimate: 25%; at least 6.5-fold (0.81 log units) between middle value and limit.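

Going by these compounds alone, compound 3 and compound 4 are both reported only as limits, and no step between them can be read. The compounds shown leave open whether 3,4-dihydroxyphenyl in place of 3,4-dimethoxyphenyl changes the tolerated concentration at all.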